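Swapping a Sulfonamide-Bearing Aryl Group for a Small Nitrile

The source may report more compounds than this note shows. Statements on the series, on what has been measured and on what is new or still open speak of the compounds shown alone.

Compound 1, `CC(C)(N)C(=O)N[C@H](COCc1ccccc1)c1nnnn1CCCc1ccccc1`: 200 nM
Compound 2, `CC(C)(N)C(=O)N[C@H](COCc1ccccc1)c1nnnn1CCC#N`: 2940 nM
Compound 3, `CC(C)(N)C(=O)N[C@H](COCc1ccccc1)c1nnn(Cc2ccccc2NS(C)(=O)=O)n1`: > 5000 nM

All three were tested in an assay on isolated protein for displacement of a labelled ligand from growth hormone secretagogue receptor type 1 (Homo sapiens), with a stated time of 1 h; a lower number here means a stronger inhibitor, a higher number a weaker inhibitor. Compound 1 gives 200 nM. Compound 2 gives 2940 nM, a 15-fold higher number from compound 1 to compound 2 (1.17 log units; beyond the scatter). For compound 3 only a limit of the assay is known, > 5000 nM, so it stands at the limit of > 5000 nM in this assay, at which 1 of the 3 values shown sits, rather than at a number.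

Compound 4, `CC(C)(N)C(=O)N[C@H](COCc1ccccc1)c1nnn(CC#N)n1`, differs from compound 3 by cyano in place of 2-(methanesulfonamido)phenyl on a saturated chain carbon bound to an aromatic nitrogen. Within the data shown here, the one measured step in this direction, a 15-fold higher number from compound 1 to compound 2 (1.17 log units; beyond the scatter), moved toward weaker binding when a nitrile replaced an aromatic group on a chain. Starting from a limit, compound 4 is therefore expected to remain weak, with an estimated value of 7000 nM in this assay, in the range 2000 nM to 25000 nM. That corresponds to an expected step that the limit leaves unreadable from compound 3 to compound 4.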

Compound 4, inhibition constant: > 5000 nM
Compound 4: only a limit was reported; the forecaster's own chance of this, stated with the estimate: 60%; the middle value lies beyond the limit too.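

Among these compounds, compound 3 and compound 4 both stand only at a limit of the assay, so no step between them can be read: the limit of > 5000 nM in this assay, at which 2 of the 4 values shown sit.

The compounds shown leave open how far past that limit each one lies, and so whether cyano or 2-(methanesulfonamido)phenyl gives the stronger binding.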